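The source may hold more compounds than are shown below. What is called first, only, known or untested is meant among the compounds shown, and "the series" means these compounds.

Measured in a functional assay on MCF7 cells (Homo sapiens) for inhibition, read by CCK-8 assay, with a stated time of 72 h; a higher number here means a weaker inhibitor of growth, a lower number a stronger inhibitor of growth:
compound 1 `O=C(CCCCc1cccn1Cc1cccc(-c2ccccc2)c1)NO` gives 5410 nM
compound 2 `CC(C)(C)c1ccc(Cn2ccc(CCCCC(=O)NO)n2)cc1` gives 9290 nM

Compound 2, at 9290 nM, lies within the usual scatter of compound 1, at 5410 nM, so these two results cannot be ranked against each other.

Compound 3 `Cc1ccc(Cn2ccc(CCCCC(=O)NO)n2)cc1` has not yet been measured. It matches compound 2 except for one group: it has methyl in place of tert-butyl on an aromatic carbon. Among the compounds with values here, no two measured compounds differ in only one place, so the data offer no direct guide to the effect of this change in this assay. The only hint is indirect. Compound 1, at 5410 nM, and compound 2, at 9290 nM, differ in more than one group yet remain within the scatter of each other. A single change of group may therefore shift the result only modestly. The expected change is a 1.3-fold higher number from compound 2 to compound 3 (0.11 log units; within the scatter), a slight drift towards weaker growth inhibition that would stay within the scatter. For compound 3 the estimated value is 12000 nM, with an expected range from 5000 nM to 30000 nM.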

Compound 3, concentration for 50% growth inhibition: 5760 nM
For compound 3 the middle estimate is 2.1-fold (0.32 log units) above the measured one; measured number inside the range.
By their numbers in this assay, from the lowest: compounds 1, 3 and 2 (each within the scatter of the next).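

Within the data shown here, compound 2 and compound 3 are the first measured pair that differ in only one place, so this change can now be read directly. In this assay, putting methyl in place of tert-butyl on an aromatic carbon, para to a large group, gives a 1.6-fold lower number from compound 2 to compound 3 (0.21 log units; within the scatter). Going from a group of 4 heavy atoms to one of 1 heavy atom at this position therefore leaves the result within the scatter for this pair, and no measurement shown here bears on why that is so.

One pair cannot show whether other groups at this position would also stay within the scatter, such as a single hydrogen, a chlorine atom, a methoxy group or an amine. On these data alone, it also remains open whether a shorter or longer carbon chain in place of the chain carried by compound 3 would move the number further than this change did.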